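The source may hold more compounds than are shown below. What is called first, only, known or untested is meant among the compounds shown, and "the series" means these compounds.

Of the compounds shown here, three of one series have been tested for how strongly they hold back the growth of a human colon cancer cell line. Compound 1 has the structure `CN(C)CCNc1nc(-c2ccc(NC(=O)Nc3ccc(Cl)cc3Cl)cc2)nc2ccsc12`. In a functional assay on HT-29 cells (Homo sapiens) for cytotoxicity, read by MTT assay, with a stated time of 72 h (a higher number here means a weaker inhibitor, a lower number a stronger inhibitor), compound 1 gives 1320 nM. Compound 2, with the structure `Cc1ccc(NC(=O)Nc2ccc(-c3nc(NCCN(C)C)c4sccc4n3)cc2)cc1`, carries one change on the same core, namely (4-methylphenyl in place of 2,4-dichlorophenyl on an amide-type nitrogen). In this assay compound 2 gives 2150 nM, so the step of a 1.6-fold higher number from compound 1 to compound 2 (0.21 log units; within the scatter) is a small one. Compound 3, with the structure `CCN(CC)CCCNc1nc(-c2ccc(NC(=O)Nc3ccc(Cl)cc3Cl)cc2)nc2c(Cl)c(Cl)sc12`, has a core unlike that of compound 1; the difference between the two cores is not broken down here. In this assay compound 3 gives 1230 nM, a number close to that of compound 1 and also close to that of compound 2.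

Compound 4, with the structure `CCN(CC)CCCNc1nc(-c2ccc(NC(=O)Nc3ccc(C)cc3)cc2)nc2c(Cl)c(Cl)sc12`, has not yet been measured. It stands to compound 3 as compound 2 stands to compound 1: the change is 4-methylphenyl in place of 2,4-dichlorophenyl on an amide-type nitrogen, and the place of the change is described in the same words for both pairs, so this is the same change, appearing twice among these compounds. Because the earlier step was a 1.6-fold higher number from compound 1 to compound 2 (0.21 log units; within the scatter), the step from compound 3 to compound 4 is expected to be of similar size, estimated as a 1.6-fold higher number from compound 3 to compound 4 (0.21 log units; within the scatter). For compound 4 the expected value in this assay is 2000 nM, with a likely range from 1000 nM to 4500 nM.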

Compound 4, half-maximal inhibitory concentration: 890 nM
Compound 4: middle estimate off by 2.2-fold (0.35 log units), on the high side; the whole stated range lies above it.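

In this assay, putting 4-methylphenyl in place of 2,4-dichlorophenyl on the amide-type nitrogen gives a 1.4-fold lower number from compound 3 to compound 4 (0.14 log units; within the scatter), so on this second core the change is again a small one. Set side by side, the two steps differ by no more than repeated measurements of this kind can be expected to: the same change on two cores in this assay, a 1.6-fold higher number (0.21 log units; within the scatter) from compound 1 to compound 2 and a 1.4-fold lower number (0.14 log units; within the scatter) from compound 3 to compound 4, 2.3-fold (0.35 log units) apart, within the scatter of two such steps. This shows that, in this assay, the change makes no clear difference on either core and that nothing here separates its effect on one core from its effect on the other, but it does not show that the effect is truly identical on both, and steps this small could hide a modest real difference, while two pairs say nothing about any further core.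

What the compounds shown leave open is whether a group of another kind on the same amide-type nitrogen, such as a phenyl ring carrying a carboxylic acid or an amine, would move the number beyond the scatter. Also open, as far as these compounds go, is whether the change would stay this small with a longer chain on the side-chain amine, or in a cell line other than the one in this assay.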